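Alkynyl chain on the amine nitrogen of compound 1

The source may report more compounds than this note shows. Statements on the series, on what has been measured and on what is new or still open speak of the compounds shown alone.

Within the data shown here, in an assay for inhibition of tRNA (cytosine(38)-C(5))-methyltransferase (Homo sapiens), with a stated time of 5 min, tested at 100 uM (on this read-out higher numbers stand for more inhibition at the one concentration tested (going by the name of the read-out) and lower numbers for less inhibition), compound 1 `CC(C)N(CC[C@H](N)C(=O)O)C[C@H]1O[C@@H](n2cnc3c(N)ncnc32)[C@H](O)[C@@H]1O` gives 44%, the lower of the two numbers measured so far; compound 2 `CC#CCN(CC[C@H](N)C(=O)O)C[C@H]1O[C@@H](n2cnc3c(N)ncnc32)[C@H](O)[C@@H]1O` gives 61.3%. Among the measured compounds shown here, only one measured step bears on the question, and it is modest: a number 17.3 percentage points higher from compound 1 to compound 2 (beyond the scatter). Compound 3 `CCC#CCN(CC[C@H](N)C(=O)O)C[C@H]1O[C@@H](n2cnc3c(N)ncnc32)[C@H](O)[C@@H]1O` carries the change (pent-2-yn-1-yl in place of isopropyl on an amine nitrogen). A rise beyond the scatter in this assay is expected for compound 3 because the closely related step was a number 17.3 percentage points higher from compound 1 to compound 2 (beyond the scatter), so the step of a number 18 percentage points higher from compound 1 to compound 3 (beyond the scatter) is estimated. Compound 3 is expected at about 62%, with a range of 46% to 78%.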

Compound 3, a percentage reported as inhibition, at one concentration (the size of the read-out at that concentration, not a potency): 62.8%
Compound 3: middle estimate off by 0.8 percentage points, on the low side, and the stated range covers the measured number.
By their numbers in this assay, from the lowest: compound 1; then compounds 2 and 3 (each within the scatter of the next).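

In this assay the gain over the isopropyl of compound 1 persists with the longer alkynyl chain (a number 18.8 percentage points higher from compound 1 to compound 3 (beyond the scatter)). Adding a methyl to the end of but-2-yn-1-yl gives no change that can be told apart (a number 1.5 percentage points higher from compound 2 to compound 3 (within the scatter)), so on this amine nitrogen the two alkynyl chains read alike. Nothing available explains the difference between the alkynyl chains and isopropyl. Open, on these data alone, is whether a saturated pentyl chain would match compound 3, which would show whether the triple bond matters. Also open, as far as these compounds go, is how a terminal amine or carboxylic acid on the chain would read.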